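The source may hold more compounds than are shown below. What is called first, only, known or untested is meant among the compounds shown, and "the series" means these compounds.

Measured compounds:
compound 1, `O=C(Nc1ccc(F)c(Cl)c1)c1cc(Cl)ccc1O`: 4400 nM
compound 2, `O=C(Nc1ccc(F)c(F)c1)c1cc(Cl)ccc1O`: 7700 nM
compound 3, `O=C(Nc1cc(F)cc(F)c1)c1cc(Cl)ccc1O`: 6100 nM

All three were tested in an ADME assay on cells (Macrophage, Mus musculus) for cytotoxicity, read by resazurin assay, with a stated time of 3 days; a higher number here means a weaker inhibitor, a lower number a stronger inhibitor. Compound 1 gives 4400 nM, compound 2 gives 7700 nM and compound 3 gives 6100 nM. Compound 1 and compound 2 differ by one change, (fluoro in place of chloro on an aromatic carbon), and that change made a 1.8-fold higher number from compound 1 to compound 2 (0.24 log units; within the scatter). Compound 3 lies within the scatter of both compound 1 and compound 2, so no order among the three can be read from these numbers. How the core of compound 3 differs from the core of compound 1 is not broken down here.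

Compound 4, `O=C(Nc1cc(F)cc(F)c1)c1cc(F)ccc1O`, has not yet been measured in this assay. It differs from compound 3 by fluoro in place of chloro on an aromatic carbon. Within the data shown here, this is the same kind of change as the one from compound 1 to compound 2, but the surroundings of the place are not the same: in the earlier pair the aromatic carbon is ortho to a fluoro group and meta to a large group, whereas in compound 4 it is meta to a large group and para to a hydroxy group.

Among the measured compounds shown here, the only guide to the size of the step is the earlier one, a 1.8-fold higher number from compound 1 to compound 2 (0.24 log units; within the scatter), which lay within the scatter. On that basis compound 4 is expected to give 9000 nM in this assay, with a plausible range from 4000 nM to 20000 nM. The estimate implies a step of a 1.5-fold higher number from compound 3 to compound 4 (0.17 log units; within the scatter).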

Compound 4, half-maximal inhibitory concentration: 9600 nM
Estimate against measurement, compound 4: 1.1-fold (0.03 log units) below, within the range that was stated.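

On the core of compound 3, fluoro in place of chloro, on an aromatic carbon meta to a large group and para to a hydroxy group, gave a 1.6-fold higher number from compound 3 to compound 4 (0.20 log units; within the scatter) in this assay. Set beside the same change on the core of compound 1, the new step does not differ from the earlier one: the same change on two cores in this assay, a 1.8-fold higher number (0.24 log units; within the scatter) from compound 1 to compound 2 and a 1.6-fold higher number (0.20 log units; within the scatter) from compound 3 to compound 4, 1.1-fold (0.05 log units) apart, within the scatter of two such steps Each step lies within the scatter, so the two pairs show only that the change carried across these two cores without a step beyond the scatter; they do not show that the change has a real effect in this series, and two pairs at differently placed aromatic carbons give no rule for other cores or other places.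

From the compounds shown here alone, all four compounds carry only chloro or fluoro on their rings, so it remains open whether a methoxy group, an amine or a carboxylic acid at the place para to the hydroxy group would give a step beyond the scatter. All four also keep the hydroxy group and the amide link, and what a methoxy group in place of that hydroxy group would give in this assay is likewise unknown.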